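The compounds below may be only part of what the source reports. "The series", "measured", "known", "first", "only" and "open" are said of these compounds alone.

Measured so far in a functional assay on LOX IMVI cells (Homo sapiens) for inhibition, read by sulforhodamine B assay, with a stated time of 48 h; a higher number here means a weaker inhibitor of growth, a lower number a stronger inhibitor of growth:
- compound 1 `O=C(Cc1csc2nc(-c3ccc(Br)cc3)cn12)N/N=C/c1ccccc1`: 12300 nM
- compound 2 `O=C(Cc1csc2nc(-c3ccc(Br)cc3)cn12)N/N=C/c1ccc(O)cc1`: 11200 nM

Compound 2, at 11200 nM, cannot be separated from compound 1, and neither ranks ahead of the other in this assay. Among the compounds with values here, the only measured step is a 1.1-fold lower number from compound 1 to compound 2 (0.04 log units; within the scatter), a hydroxy in place of hydrogen on an aromatic carbon.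

Compound 3 `COc1cccc(OC)c1/C=N/NC(=O)Cc1csc2nc(-c3ccc(Br)cc3)cn12` keeps the shared core and the hydrazone-type linker of compound 2 and changes only the terminal aryl group: 2,6-dimethoxyphenyl in place of 4-hydroxyphenyl on a carbon with a double bond to nitrogen. In words, 2,6-dimethoxyphenyl stands in place of 4-hydroxyphenyl on a carbon with a double bond to nitrogen.

Within the data shown here, the one measured step concerns the same terminal group, and it stays within the scatter: a 1.1-fold lower number from compound 1 to compound 2 (0.04 log units; within the scatter). Among the measured compounds shown here, it is weak evidence, since no measured compound carries a methoxy group and a single pair cannot show how far this position tolerates change. With nothing pointing either way, no direction is favoured, and the expected result is a 1.0-fold lower number from compound 2 to compound 3 (0.01 log units; within the scatter).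

For compound 3 the estimated value is 11000 nM, with an expected range of 4000 nM to 30000 nM.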

Compound 3, concentration for 50% growth inhibition: 12600 nM
For compound 3 the middle estimate is 1.1-fold (0.06 log units) below the measured one, within the range that was stated.
By their numbers in this assay, from the lowest: compounds 2, 1 and 3 (each within the scatter of the next).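

In this assay the terminal aryl group on the carbon with a double bond to nitrogen now has a much larger replacement, and the result is a 1.1-fold higher number from compound 2 to compound 3 (0.05 log units; within the scatter) for 2,6-dimethoxyphenyl in place of 4-hydroxyphenyl and a 1.0-fold higher number from compound 1 to compound 3 (0.01 log units; within the scatter) for 2,6-dimethoxyphenyl in place of phenyl. The earlier pair covered only a hydroxy in place of hydrogen, whereas this change goes from 7 to 10 heavy atoms and from 1 hydrogen-bond donor to 0, and the three compounds still cannot be separated, so neither the loss of the donor nor the two methoxy groups registers in this read-out. No accompanying measurement bears on why this position gives such a flat result.

Open, on these data alone, is whether any terminal group moves the number out of the scatter, for instance an amine or a carboxylic acid on the ring, or a saturated ring such as cyclohexyl in place of the aryl group. As far as these compounds go, all three compounds also share the same core, so it remains unknown whether this flat response would hold with a different group in place of the bromine.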